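Removing a methyl from a thiosemicarbazide-type pyrazoline

A few compounds are considered here, and "the series" means these few. Any claim that something is new, unique, unknown or untested is made for them only; others in the source may bear on it.

Measured compounds:
- compound 1, `CNC(=S)N1CC(C)C(c2ccc(F)cc2)=N1`: "not active" (no number reported)
- compound 2, `CNC(=S)N1CC(C)C(c2ccc(OC)cc2)=N1`: "not active" (no number reported)
- compound 3, `CNC(=S)N1CC(C)C(c2ccc(C)cc2)=N1`: 40%

Of the compounds shown here, three sharing one core have been tested in an in vitro assay on cells for inhibition of Amine oxidase [flavin-containing] A (Homo sapiens), read by Amplex Red, with a stated time of 15 min, tested at 100 uM; a lower number here means less inhibition, a higher number more inhibition at the concentration tested (going by the name of the read-out). Compound 1 and compound 2 gave no number, only the report that they were not active. Compound 3 is therefore the only one of the three with a numerical result, and in this assay compound 3 gives 40%, which stands on its own with nothing to rank it against.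

Compound 4, `CNC(=S)N1CC(C)C(c2ccccc2)=N1`, is the next step from compound 3. The change is hydrogen in place of methyl on an aromatic carbon: methyl leaves and hydrogen enters on an aromatic carbon of a six-membered aromatic ring of carbon only. Among the compounds with values here, no step between two measured compounds exists to show what such a change does in this assay. Since compound 1 and compound 2 gave no number while compound 3 gave 40%, a modest drop in inhibition is expected for compound 4, although one within or just beyond the scatter would not surprise. The expected step is a number 15 percentage points lower from compound 3 to compound 4 (beyond the scatter). Compound 4 is estimated at 25%, between 5% and 48%.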

Compound 4, a percentage reported as inhibition, at one concentration (the size of the read-out at that concentration, not a potency): "not active" (no number reported)
Nothing numeric was reported for compound 4; no gap can be computed for the estimate.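

In this assay, within the data shown here, compound 4 is reported as not active, without a number, so no step from compound 3 to compound 4 can be read. Nothing measured here offers an explanation for this result. The compounds shown leave open how much the methyl of compound 3 matters for inhibition.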